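A few compounds are considered here, and "the series" means these few. Any claim that something is new, unique, unknown or untested is made for them only; others in the source may bear on it.

Measured so far:
- compound 1 `COc1cc(C(=O)O)ccc1Cn1ccc2ccc(NC(=O)OC3CCCC3)cc21`: 160 nM
- compound 2 `COc1cc(C(=O)NS(=O)(=O)c2ccccc2C)ccc1Cc1cn(C)c2ccc(NC(=O)NC3CCCC3)cc12`: 1.4 nM

In an assay on lung parenchyma for displacement of a labelled ligand from cysteinyl leukotriene receptor 1 (Cavia porcellus) (on this read-out higher numbers stand for weaker inhibition and lower numbers for stronger inhibition), compound 1 gives 160 nM, the higher of the two numbers; compound 2 sits far lower and differs from compound 1 in several places at once, so its value alone does not isolate any single change.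

Compound 3 `COc1cc(C(=O)O)ccc1Cn1ccc2ccc(NC(=O)CC3CCCC3)cc21` differs from compound 1 by cyclopentylmethyl in place of cyclopentyloxy on a carbonyl carbon. With the ring kept and only the link to the carbonyl altered, no step beyond the scatter in this assay is expected, with a slight lean towards a weaker number. Compound 3 is estimated at 220 nM (range 70 nM to 700 nM), a step of a 1.4-fold higher number from compound 1 to compound 3 (0.14 log units; within the scatter).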

Compound 3, inhibition constant: 200 nM
Compound 3: the middle estimate sits 1.1-fold (0.04 log units) above what was measured; the range from low to high includes it.
By their numbers in this assay, from the lowest: compound 2; then compounds 1 and 3 (each within the scatter of the next).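

In this assay, cyclopentylmethyl in place of cyclopentyloxy on a carbonyl carbon gives a 1.3-fold higher number from compound 1 to compound 3 (0.10 log units; within the scatter) on the core of compound 1, so this one change leaves the read-out within the scatter. The hydrogen-bond acceptor counted on cyclopentyloxy is absent from cyclopentylmethyl, yet the two values are not separated. Nothing measured on these compounds offers an explanation for this result.

Still open, as far as these compounds go, is how this position responds to a cyclohexyl ring or an open butyl chain on the carbonyl carbon. The gap to compound 2 also remains unassigned, as compound 2 differs in several places at once.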